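A few compounds are considered here, and "the series" means these few. Any claim that something is new, unique, unknown or untested is made for them only; others in the source may bear on it.

Measured so far:

Compound 1, `Cc1ccc(CS/C(=C/c2ccccc2F)C(=O)c2ccc(Cl)cc2)cc1`, gives 10000 nM in a functional assay on DU-145 cells (Homo sapiens) for inhibition, read by trypan blue exclusion, with a stated time of 96 h; a higher number here means a weaker inhibitor of growth, a lower number a stronger inhibitor of growth.
Compound 2, `Cc1ccc(CS/C(=C/c2cc([N+](=O)[O-])ccc2F)C(=O)c2ccc(Cl)cc2)cc1`, gives 1000 nM.
Compound 3, `CN(C)c1ccc(/C=C(/Sc2ccccc2Br)C(=O)c2ccc(Br)cc2)cc1`, reaches only a limit of this assay, > 100000 nM.

Compound 2 stands lowest of the two numbers shown; its nearest neighbour is compound 1, which sits at a higher number. Within the data shown here, the one measured step, a 10-fold lower number from compound 1 to compound 2 (1.00 log units; beyond the scatter), is the only evidence bearing on the change under consideration. Compound 4, `Cc1ccc(CS/C(=C/c2cccc(Cl)c2Cl)C(=O)c2ccc(Cl)cc2)cc1`, is not yet measured. It differs from compound 2 as follows: 2,3-dichlorophenyl in place of 2-fluoro-5-nitrophenyl on a double-bonded chain carbon bound to a double-bonded chain carbon. The nitro group whose arrival lowered the number from compound 1 to compound 2 leaves in compound 4, while the two chlorines that enter have no measured counterpart among these compounds. Among the measured compounds shown here, compound 3 offers no step, since its value is only a limit. Compound 4 is therefore expected to move back toward compound 1, with the step of a 5.0-fold higher number from compound 2 to compound 4 (0.70 log units; beyond the scatter) expected to be beyond the scatter. Compound 4 is estimated at 5000 nM, within 1500 nM to 20000 nM.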

Compound 4, concentration for 50% growth inhibition: 25000 nM
Estimate against measurement, compound 4: 5.0-fold (0.70 log units) below, and the stated range ends below it.
By their numbers in this assay, from the lowest: compound 2; then compound 1; then compound 4. At a limit, above all of these: compound 3.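

Replacing 2-fluoro-5-nitrophenyl with 2,3-dichlorophenyl on this double-bonded chain carbon gives a 25-fold higher number from compound 2 to compound 4 (1.40 log units; beyond the scatter) in this assay, so the loss goes beyond what removing the nitro group alone might have suggested. Against the 2-fluorophenyl group, 2,3-dichlorophenyl gives a 2.5-fold higher number from compound 1 to compound 4 (0.40 log units; beyond the scatter), which places compound 4 beyond compound 1 rather than between compound 1 and compound 2, and shows that this position can move the number in either direction from compound 1. Nothing measured here accounts for these shifts.

On these data alone, it remains open whether one chlorine alone would produce the same rise, or whether both are needed. As far as these compounds go, it is also open whether an amine or a nitrile on this aromatic ring would keep a number as low as that of compound 2.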